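A few compounds are considered here, and "the series" means these few. Any claim that something is new, unique, unknown or untested is made for them only; others in the source may bear on it.

In a functional assay on HeLa cells (Homo sapiens) for cytotoxicity, read by MTT assay, with a stated time of 72 h (on this read-out higher numbers stand for weaker inhibition and lower numbers for stronger inhibition), compound 3 `Cn1ccc2c(Oc3ccc(NC(=O)c4cc5cccnc5n(-c5ccc(C(F)(F)F)c(Cl)c5)c4=O)cc3F)ncnc21` gives 156000 nM and stands within the scatter of compound 1 `Cn1ccc2c(Oc3ccc(NC(=O)c4cc5cccnc5n(-c5ccc(C(F)(F)F)cc5Cl)c4=O)cc3)ncnc21` with 174000 nM and well above compound 2 `Cn1ccc2c(Oc3ccc(NC(=O)c4cc5cccnc5n(-c5ccc(Br)cc5)c4=O)cc3F)ncnc21` with 33800 nM on this scale. Compound 4 `Cn1ccc2c(Oc3ccc(NC(=O)c4cc5cccnc5n(-c5ccc(C(F)(F)F)cc5Cl)c4=O)cc3F)ncnc21` has the same atoms joined differently (2-chloro-4-(trifluoromethyl)phenyl in place of 3-chloro-4-(trifluoromethyl)phenyl on an aromatic nitrogen): 2-chloro-4-(trifluoromethyl)phenyl in place of 3-chloro-4-(trifluoromethyl)phenyl on an aromatic nitrogen. Within the data shown here, the only measured step at this place is a 4.6-fold higher number from compound 2 to compound 3 (0.66 log units; beyond the scatter) and it replaced 4-bromophenyl, a larger exchange than this one. Compound 1 already bears 2-chloro-4-(trifluoromethyl)phenyl and gives 174000 nM on a core that is not identical, within the scatter of compound 3. No step beyond the scatter is therefore expected in this assay and no firm direction either. The estimated step is a 1.0-fold lower number from compound 3 to compound 4 (0.02 log units; within the scatter) and it stays small. For compound 4 the estimated value is 150000 nM (range 70000 nM to 300000 nM).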

Compound 4, half-maximal inhibitory concentration: 170000 nM
Compound 4: middle estimate off by 1.1-fold (0.05 log units), on the low side; the measured number falls inside the stated range.
By their numbers in this assay, from the lowest: compound 2; then compounds 3, 4 and 1 (each within the scatter of the next).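

In this assay the swap of 3-chloro-4-(trifluoromethyl)phenyl for 2-chloro-4-(trifluoromethyl)phenyl on the aromatic nitrogen gives a 1.1-fold higher number from compound 3 to compound 4 (0.04 log units; within the scatter) and so shows no measurable change from rearranging these same atoms. The exchange of 4-bromophenyl for 2-chloro-4-(trifluoromethyl)phenyl gives a 5.0-fold higher number from compound 2 to compound 4 (0.70 log units; beyond the scatter) and stays beyond the scatter with this arrangement too. Fluoro in place of hydrogen on an aromatic carbon gives a 1.0-fold lower number from compound 1 to compound 4 (0.01 log units; within the scatter) and is the first reading of that exchange, with no change seen. Going by these compounds, how an unsubstituted phenyl or 4-methoxyphenyl at this nitrogen would read remains open. No evidence here explains these numbers.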